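The source may report more compounds than this note shows. Statements on the series, on what has been measured and on what is new or still open speak of the compounds shown alone.

Measured compounds in a functional assay on HT-29 cells (Homo sapiens) for cytotoxicity, read by sulforhodamine B assay, with a stated time of 2 days, tested at 100 uM; a higher number here means more inhibition at the concentration tested (going by the name of the read-out), a lower number less inhibition:
compound 1 `COc1cccc(-c2nc3c(-c4ccc(Cl)cc4)n[nH]c3c(=O)n2NC(=O)c2ccncc2)c1` gives 46%
compound 2 `CCCc1n[nH]c2c(=O)n(NC(=O)c3ccccc3)c(-c3cccc(OC)c3)nc12` gives 6.27%
compound 3 `COc1cccc(-c2nc3c(-c4ccc(Cl)cc4)n[nH]c3c(=O)n2NC(=O)c2ccccc2)c1` gives 87.3%

Compound 3 stands highest of these three numbers, and both steps that lead to it are large: a number 41.3 percentage points higher from compound 1 to compound 3 (beyond the scatter) and a number 81 percentage points higher from compound 2 to compound 3 (beyond the scatter), each beyond the scatter. Compound 4 `COc1cccc(Cc2nc3c(-c4ccc(Cl)cc4)n[nH]c3c(=O)n2NC(=O)c2ccccc2)c1` differs from compound 3 by 3-methoxybenzyl in place of 3-methoxyphenyl on an aromatic carbon. Within the data shown here, neither measured step touches this position: one changes the group on the carbonyl carbon, the other the group on a different aromatic carbon of the core, so no measured step bears directly on the change, and the direction is open. Some loss beyond the scatter is considered more likely than a gain. Compound 4 is therefore expected to give about 55%, between 15% and 88%. This expectation corresponds to a step of a number 32.3 percentage points lower from compound 3 to compound 4 (beyond the scatter).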

Compound 4, a percentage reported as inhibition, at one concentration (the size of the read-out at that concentration, not a potency): 89.3%
Estimate against measurement, compound 4: 34.3 percentage points below; the measured number lies above the stated range.
By their numbers in this assay, from the lowest: compound 2; then compound 1; then compounds 3 and 4 (each within the scatter of the next).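

In this assay, the place between two ring nitrogen atoms accepts 3-methoxybenzyl in place of 3-methoxyphenyl with a number 2 percentage points higher from compound 3 to compound 4 (within the scatter) and the read-out stays high. Among these compounds, the earlier steps changed other places, so this is the first reading here, and it holds with the 4-chlorophenyl and benzamido groups kept fixed. Nothing measured here gives a reason for this result.

On these data alone, whether an amine, a carboxylic acid or a longer chain at this place would keep the read-out remains open. So does whether the same change would behave alike with propyl or pyridin-4-yl elsewhere on the compound.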